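Cyano for Trifluoromethyl in a Set Without Measured Activity

This account rests on a few compounds, and the source may have more. Where it says the series, first, only, none or still open, it means among the compounds named here.

Three compounds share one core and differ only in the side chain. Compound 1 `Cc1cc(=O)oc2cc(SC3CCOC3=O)ccc12`, compound 2 `Cc1cc(=O)oc2cc(SCc3ccncc3)ccc12` and compound 3 `Cc1cc(=O)oc2cc(SCc3cccc(C(F)(F)F)c3)ccc12` were each tested in a functional assay on KB cells (Homo sapiens) for antiproliferative activity, read by sulforhodamine B assay, with a stated time of 72 h; on this read-out higher numbers stand for weaker inhibition of growth and lower numbers for stronger inhibition of growth. In this assay compound 1 gives only a limit, > 36100 nM, and not a number. For compound 2 this assay likewise records only a limit, > 35200 nM. Compound 3 also reaches only a limit, > 28500 nM. Compound 3 therefore stands nowhere apart from its companions: all three values are limits, and no ordering among them can be read.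

Compound 4 `Cc1cc(=O)oc2cc(SCc3cccc(C#N)c3)ccc12` has not been measured. It differs from compound 3 by cyano in place of trifluoromethyl on an aromatic carbon. Going by the values given here, compound 1, compound 2 and compound 3 all stop at a limit, as the limit of > 28500 nM in this assay, at which 1 of the 3 values shown sits, the limit of > 35200 nM in this assay, at which 1 of the 3 values shown sits, and the limit of > 36100 nM in this assay, at which 1 of the 3 values shown sits, show, so no measured step within this set offers guidance on how such an exchange shifts the read-out. The expected change is a step that the limit leaves unreadable from compound 3 to compound 4, which is nothing beyond the usual scatter. Compound 4 is expected to give 40000 nM in this assay, with a range from 15000 nM to 100000 nM, and most likely only a limit will again be reported.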

Compound 4, concentration for 50% growth inhibition: > 32500 nM
Compound 4: a limit, no number; the forecaster's own chance of this, stated with the estimate: 85%; the middle value is on the limit's open side.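

No step can be read from compound 3 to compound 4 in this assay: both give only limits, not numbers. The compounds shown leave open how cyano and trifluoromethyl on an aromatic carbon truly compare, and whether any side chain on the shared core can give an actual number in this assay.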